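Chloro on a pyridinyl anilide: expected growth inhibition

A few compounds are considered here, and "the series" means these few. Any claim that something is new, unique, unknown or untested is made for them only; others in the source may bear on it.

Measured compounds:
compound 1, `O=C(CCCCC(S)CCS)Nc1ccccc1`, 8.37%
compound 2, `O=C(CCCCC(S)CCS)Nc1ccc(Cl)cc1`, 22%
compound 3, `O=C(CCCCC(S)CCS)Nc1ccccn1`, "not active" (no number reported) (no number reported)

All three were tested in a functional assay on NCI-H460 cells (Homo sapiens) for inhibition, read by MTT assay, with a stated time of 24 h, tested at 10 ug/mL; a higher number here means more inhibition of growth at the concentration tested, a lower number less inhibition of growth. Compound 1 and compound 2 differ by chloro in place of hydrogen on an aromatic carbon, and the step of a number 13.6 percentage points higher from compound 1 to compound 2 (beyond the scatter). Compound 3 differs from compound 1 by pyridin-2-yl in place of phenyl on an amide-type nitrogen, and in this assay compound 3 is recorded only as "not active" (no number reported), without a number.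

Compound 4, `O=C(CCCCC(S)CCS)Nc1ccc(Cl)cn1`, is not yet measured. It differs from compound 3 by chloro in place of hydrogen on an aromatic carbon, the same kind of change as from compound 1 to compound 2, though here the place is on a ring with one nitrogen, two atoms from the ring nitrogen, rather than on a ring of carbon only. Compound 3 has no number. Among the measured compounds shown here, the only measured step of this kind is a number 13.6 percentage points higher from compound 1 to compound 2 (beyond the scatter), a modest rise. The expectation for compound 4 rests on that step alone. Compound 4 is therefore expected to give about 15%, estimated between 0% and 35%.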

Compound 4, percent growth inhibition at one concentration: 27.4%
Compound 4: the middle estimate sits 12.4 percentage points below what was measured; the measured number falls inside the stated range.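

Compound 3 carries no number, so the change from compound 3 to compound 4 cannot be read as a step. The compounds leave open what chloro does on the ring with one nitrogen, and no measurement shown here explains the result for compound 4.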